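Removing a Methyl Group from the Shared Core

The compounds below may be only part of what the source reports. "The series", "measured", "known", "first", "only" and "open" are said of these compounds alone.

Compound 1 `Cc1nsc2c1nc(SCc1ccccc1)n2[C@H]1C[C@H](O)[C@@H](CO)O1` reaches only the limit > 100000 nM in a functional assay on L1210 cells (Mus musculus) for antiproliferative activity; on this read-out lower numbers stand for stronger inhibition and higher numbers for weaker inhibition. Compound 2 `OC[C@H]1O[C@@H](n2c(SCc3ccccc3)nc3cnsc32)C[C@@H]1O` gives 8000 nM in this assay. Compound 3 `CSc1nc2snc(C)c2n1[C@H]1C[C@H](O)[C@@H](CO)O1` gives 33000 nM in this assay.

Among the compounds with values here, only three compounds are measured. Compound 1 sits at the limit of this assay (the limit of > 100000 nM in this assay, at which 1 of the 3 values shown sits), so its value is not a number. The change hydrogen in place of methyl on an aromatic carbon gives an at least 12-fold lower number from compound 1 to compound 2 (1.09 log units; beyond the scatter); since compound 1 is a limit, the true size of that step is not known, only that it is large. Between the two compounds with numbers, compound 3 gives the higher one. Compound 1 and compound 3 have different cores; the difference between the two cores is not broken down here.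

Compound 4 `CSc1nc2sncc2n1[C@H]1C[C@H](O)[C@@H](CO)O1` is not yet measured. It differs from compound 3 by hydrogen in place of methyl on an aromatic carbon, the same change as from compound 1 to compound 2. Resting on an at least 12-fold lower number from compound 1 to compound 2 (1.09 log units; beyond the scatter), a drop in number is expected, of a size a 6.6-fold lower number from compound 3 to compound 4 (0.82 log units; beyond the scatter), though the uncertainty of a limit-based step is carried along. Compound 4 is therefore estimated at 5000 nM, in the range 1000 nM to 25000 nM.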

Compound 4, half-maximal inhibitory concentration: 20000 nM
Compound 4: the middle estimate sits 4.0-fold (0.60 log units) below what was measured, within the range that was stated.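

In this assay, replacing the methyl with hydrogen on the core of compound 3 gives a 1.7-fold lower number from compound 3 to compound 4 (0.22 log units; within the scatter), so the two compounds cannot be told apart on this read-out. The change therefore does not carry a single step size from one core to the other, and the large step seen on the first core does not reappear on the second: the same change on two cores in this assay, an at least 12-fold lower number (1.09 log units; beyond the scatter) from compound 1 to compound 2 and a 1.7-fold lower number (0.22 log units; within the scatter) from compound 3 to compound 4, at least 7.5-fold (0.87 log units) apart, beyond the scatter of two such steps. Compound 1 is only a limit, so the true size of the first step remains unknown, and these two pairs give neither a general rule for other cores nor a reason for the gap: the limit of > 100000 nM in this assay, at which 1 of the 4 values shown sits.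

Going by these compounds, only methyl and hydrogen appear on this aromatic carbon, and how an ethyl group, a chlorine atom or an amine would read there remains open. Also open, on these data alone, is how the change from methyl to hydrogen would behave on any further core, for instance one bearing a longer chain.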